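Tosylurea chalcones against brine shrimp: a pyrrole analogue

This account rests on a few compounds, and the source may have more. Where it says the series, first, only, none or still open, it means among the compounds named here.

Measured compounds:
compound 1, `Cc1ccc(S(=O)(=O)NC(=O)Nc2ccccc2C(=O)/C=C/c2ccc(O)cc2)cc1`, 24.3 ug/mL
compound 2, `Cc1ccc(S(=O)(=O)NC(=O)Nc2ccccc2C(=O)/C=C/c2cccc([N+](=O)[O-])c2)cc1`, 44.5 ug/mL
compound 3, `Cc1ccc(S(=O)(=O)NC(=O)Nc2ccccc2C(=O)/C=C/c2ccc(Cl)cc2)cc1`, 6.92 ug/mL

In an ADME assay on the whole organism for cytotoxicity, with Artemia salina as the target, with a stated time of 24 h (a lower number here means that less compound is needed, a higher number that more compound is needed for the effect), compound 1 stands second highest of the three numbers, within the scatter of compound 2 and clearly above compound 3. Compound 4, `Cc1ccc(S(=O)(=O)NC(=O)Nc2ccccc2C(=O)/C=C/c2ccc[nH]2)cc1`, keeps the shared core of compound 1 and differs only in the group on the chain: 1H-pyrrol-2-yl in place of 4-hydroxyphenyl on a double-bonded chain carbon bound to a double-bonded chain carbon. Two measured steps replace the same 4-hydroxyphenyl group. The step of a 1.8-fold higher number from compound 1 to compound 2 (0.26 log units; within the scatter) stays within the scatter, while a 3.5-fold lower number from compound 1 to compound 3 (0.55 log units; beyond the scatter) is a modest lowering. Among the measured compounds shown here, a five-membered heteroaryl has no measured precedent here, so little shift is expected for compound 4; the step of a 1.0-fold higher number from compound 1 to compound 4 (0.01 log units; within the scatter) is estimated. Compound 4 is thus expected to give about 25 ug/mL, between 10 ug/mL and 60 ug/mL.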

Compound 4, concentration for half-maximal effect: 32.1 ug/mL
Estimate against measurement, compound 4: 1.3-fold (0.11 log units) below; low and high end bracket the measured number.
By their numbers in this assay, from the lowest: compound 3; then compounds 1, 4 and 2 (each within the scatter of the next).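

In this assay the five-membered 1H-pyrrol-2-yl ring fits with the six-membered aromatic rings at this place, since a 1.3-fold higher number from compound 1 to compound 4 (0.12 log units; within the scatter) and a 1.4-fold lower number from compound 2 to compound 4 (0.14 log units; within the scatter) both stay within the scatter. Only the 4-chlorophenyl group stands apart, with a 4.6-fold higher number from compound 3 to compound 4 (0.67 log units; beyond the scatter) lying beyond the scatter, so a smaller ring here does not by itself shift the number in these compounds. Nothing available explains these numbers.

As far as these compounds go, it remains open whether a furan-2-yl or thiophen-2-yl ring would fall with compound 4 or with compound 3. From the compounds shown here alone, whether a chloro on the pyrrole would lower the number is also open.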